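This account rests on a few compounds, and the source may have more. Where it says the series, first, only, none or still open, it means among the compounds named here.

For the measured compounds named here, in a functional assay on DLD-1 cells (Homo sapiens) for cytotoxicity, read by MTT assay (on this read-out higher numbers stand for weaker inhibition and lower numbers for stronger inhibition), compound 2 `COc1cc(/C=C/C(=O)C(=Cc2ccc(O)c(O)c2)C(=O)/C=C/c2ccc(O)c(OC)c2)ccc1O` gives 17600 nM, the higher of the two numbers so far, and compound 1 `CCOc1cc(C=C(C(=O)/C=C/c2ccc(O)c(OC)c2)C(=O)/C=C/c2ccc(O)c(OC)c2)ccc1O` gives 4260 nM. Compound 2 is therefore the weaker of the measured pair on this read-out.

Compound 3 `CCOc1ccc(C=C(C(=O)/C=C/c2ccc(O)c(OC)c2)C(=O)/C=C/c2ccc(O)c(OC)c2)cc1OCC` is the next to be read. Relative to compound 2 it carries 3,4-diethoxyphenyl in place of 3,4-dihydroxyphenyl on a double-bonded chain carbon bound to a double-bonded chain carbon, that is, 3,4-diethoxyphenyl in place of 3,4-dihydroxyphenyl on a double-bonded chain carbon bound to a double-bonded chain carbon.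

Going by the values given here, one measured step bears on this change: a 4.1-fold higher number from compound 1 to compound 2 (0.62 log units; beyond the scatter), with hydrogen in place of ethyl on an oxygen on an aromatic ring. The change to compound 3 runs the other way, with ethyl replacing hydrogen, so a modest move to a lower number in this assay is expected, of roughly the size of that single step. Among the compounds with values here, no measured compound carries 3,4-diethoxyphenyl, and one step gives thin support, so the range stays wide. The expected step is a 3.5-fold lower number from compound 2 to compound 3 (0.55 log units; beyond the scatter). In this assay the estimate for compound 3 is 5000 nM, with an expected range of 1800 nM to 14000 nM.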

Compound 3, half-maximal inhibitory concentration: 4120 nM
Compound 3: the middle estimate sits 1.2-fold (0.08 log units) above what was measured, and the stated range covers the measured number.
By their numbers in this assay, from the lowest: compounds 3 and 1 (each within the scatter of the next); then compound 2.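

In this assay, exchanging 3,4-dihydroxyphenyl for 3,4-diethoxyphenyl on a double-bonded chain carbon bound to a double-bonded chain carbon gives a 4.3-fold lower number from compound 2 to compound 3 (0.63 log units; beyond the scatter) and so matches in size the single-ethyl step read in the opposite direction, a 4.1-fold higher number from compound 1 to compound 2 (0.62 log units; beyond the scatter) with one ethyl already enough to account for the whole difference. Ethyl on the remaining oxygen gives a 1.0-fold lower number from compound 1 to compound 3 (0.01 log units; within the scatter) and so compound 1 and compound 3 cannot be told apart, which means that at this place the number does not follow the count of ethyl groups in a simple additive way across these three compounds. Nothing in the data shown gives a reason for this levelling.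

Open, going by these compounds, is whether it matters which of the two oxygens carries the single ethyl, and whether methyl or a longer chain such as butyl on these oxygens would read the same as ethyl. Also open, on these data alone, is whether an amine or a carboxylic acid on this ring would reach beyond the level shared by compound 1 and compound 3 or fall back towards compound 2.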